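The source may hold more compounds than are shown below. What is called first, only, known or untested is meant among the compounds shown, and "the series" means these compounds.

Of the compounds shown here, two that share one core have been measured so far. Compound 1 `Cc1cc(F)cc(Nc2cc(NC(=O)Nc3c(Cl)cccc3Cl)ncn2)c1` was tested in a functional assay on NCI-H1581 cells (Homo sapiens) for inhibition, read by MTT assay, with a stated time of 48 h, tested at 10 uM (on this read-out higher numbers stand for more inhibition at the one concentration tested (going by the name of the read-out) and lower numbers for less inhibition), where compound 1 gives 65.1%. Compound 2 `CC(C)(C)c1ccc(Nc2cc(NC(=O)Nc3c(Cl)cccc3Cl)ncn2)cc1` was tested in the same way, and in this assay compound 2 gives 71.3%. Compound 2 holds the higher of the two numbers shown, but its only neighbour, compound 1, sits within the usual scatter of repeated measurements, so the two cannot truly be set apart. Compound 3 `CCc1ccc(Nc2cc(NC(=O)Nc3c(Cl)cccc3Cl)ncn2)cc1` has not yet been measured. It differs from compound 2 in one place: ethyl in place of tert-butyl on an aromatic carbon. For the measured compounds named here, no pair of measured compounds shows the effect of such a change, so the expectation rests on the values above alone. The step from compound 2 to compound 3 in this assay is expected to be a number 8.3 percentage points lower from compound 2 to compound 3 (within the scatter), small and at most a slight downward drift within the scatter. Compound 3 is estimated at 63%, with a likely range from 46% to 78%.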

Compound 3, a percentage reported as inhibition, at one concentration (the size of the read-out at that concentration, not a potency): 38.1%
The estimate for compound 3 lay 24.9 percentage points above the measured number, outside the stated range (below it).
By their numbers in this assay, from the lowest: compound 3; then compounds 1 and 2 (each within the scatter of the next).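

In this assay, the group on this aromatic carbon, para to a large group, clearly matters: ethyl in place of tert-butyl brings a number 33.2 percentage points lower from compound 2 to compound 3 (beyond the scatter). The aryl group on the nitrogen matters as well, since 4-ethylphenyl in place of 3-fluoro-5-methylphenyl brings a number 27 percentage points lower from compound 1 to compound 3 (beyond the scatter), so compound 3 stands apart from two compounds that could not be told apart from each other. Nothing available here explains why the number falls with this change.

On these data alone, with only tert-butyl and ethyl to compare at this position, it remains open whether the number changes gradually or abruptly between them. An isopropyl group, a longer chain such as n-butyl, or an amine at the same carbon would help to show which.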